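The source may report more compounds than this note shows. Statements on the series, on what has been measured and on what is new or still open speak of the compounds shown alone.

Three compounds share one core and differ only in the aryl group on the carbonyl carbon. In an assay on microsomes from liver for inhibition of sterol O-acyltransferase 1 (Rattus norvegicus) (on this read-out lower numbers stand for stronger inhibition and higher numbers for weaker inhibition), compound 1 `CCCCCCCCCCCCn1nnc(C(NC(=O)c2c(C(C)C)cccc2C(C)C)c2ccccc2)n1` gives 810 nM, compound 2 `CCCCCCCCCCCCn1nnc(C(NC(=O)c2ccc(F)cc2F)c2ccccc2)n1` gives 490 nM, and compound 3 `CCCCCCCCCCCCn1nnc(C(NC(=O)c2ccc(OC)cc2)c2ccccc2)n1` gives 600 nM. Compound 3 sits within the scatter of both neighbours: a 1.4-fold lower number from compound 1 to compound 3 (0.13 log units; within the scatter) and a 1.2-fold higher number from compound 2 to compound 3 (0.09 log units; within the scatter), as does a 1.7-fold lower number from compound 1 to compound 2 (0.22 log units; within the scatter). Compound 4 `CCCCCCCCCCCCn1nnc(C(NC(=O)c2ccc(C(F)(F)F)cc2)c2ccccc2)n1` carries the next change on that ring, (trifluoromethyl in place of methoxy on an aromatic carbon). Every measured change at this position has stayed within the scatter, so no step beyond it is expected in this assay for compound 4 either. Compound 4 is therefore estimated at 560 nM, with a range from 250 nM to 1250 nM. The expected step is a 1.1-fold lower number from compound 3 to compound 4 (0.03 log units; within the scatter).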

Compound 4, half-maximal inhibitory concentration: 850 nM
Beside the measured number, compound 4's estimate is 1.5-fold (0.18 log units) below it, within the range that was stated.
By their numbers in this assay, from the lowest: compounds 2, 3, 1 and 4 (each within the scatter of the next).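

In this assay, trifluoromethyl, which has 0 hydrogen-bond acceptors, in place of methoxy, which has 1, gives a 1.4-fold higher number from compound 3 to compound 4 (0.15 log units; within the scatter), so this first change of the group on the aromatic carbon itself also stays within the scatter. Compound 4 is likewise within the scatter of the other two aryl amides, with a 1.7-fold higher number from compound 2 to compound 4 (0.24 log units; within the scatter) and a 1.0-fold higher number from compound 1 to compound 4 (0.02 log units; within the scatter), so all four aryl groups remain unresolved in this read-out. Nothing available explains the size of these steps. The compounds shown leave open whether an amine or a carboxylic acid on that aromatic carbon would give a step beyond the scatter.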